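A few compounds are considered here, and "the series" means these few. Any claim that something is new, unique, unknown or untested is made for them only; others in the source may bear on it.

Measured so far in a toxicity assay on RMS13 cells (Homo sapiens) for inhibition, with a stated time of 24 h; on this read-out higher numbers stand for weaker inhibition of growth and lower numbers for stronger inhibition of growth:
compound 1 `CC1=C(C(=O)OCc2ccccc2)C(c2ccc(-c3ccccc3C)cc2)NC(=S)N1Cc1ccc(-c2nnn[nH]2)cc1` — 68000 nM
compound 2 `CC1=C(C(=O)OCc2ccccc2)C(c2ccc(-c3ccccc3)cc2)NC(=S)N1Cc1ccc(-c2nnn[nH]2)cc1` — 87000 nM
compound 3 `CC1=C(C(=O)OCc2ccccc2)C(c2ccc(-c3ccccc3)cc2)NC(=O)N1Cc1ccc(-c2nnn[nH]2)cc1` — 96000 nM

Compound 1 gives the lowest number of the three, but it stands apart from neither neighbour: the move a 1.3-fold higher number from compound 1 to compound 2 (0.11 log units; within the scatter) is within the scatter, and compound 3 sits within the scatter of compound 1 as well. Among the measured compounds shown here, the three values therefore describe one flat level, with no compound set apart from the others.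

Compound 4 `CC1=C(C(=O)OCc2ccccc2)C(c2ccc(-c3ccccc3C)cc2)NC(=S)N1CCCCCc1nnn[nH]1` has not been measured in this assay. It differs from compound 1 in one place: 4-(1H-tetrazol-5-yl)butyl in place of 4-(1H-tetrazol-5-yl)phenyl on a saturated chain carbon bound to an amide-type nitrogen in a ring. The shared core, the benzyl ester, the methyl-bearing biaryl arm and the thione are all kept.

For the measured compounds named here, none of the measured steps touches this arm. The step from compound 1 to compound 2 alters the biaryl ring; compound 2 and compound 3 differ in the thione against the carbonyl, and their two values lie close together. Every change seen so far has left the number where it was. Going by the values given here, on that record, and with no step on the tetrazole-bearing arm to lean on, compound 4 is expected to remain on the same flat level, with the step of a 1.2-fold higher number from compound 1 to compound 4 (0.07 log units; within the scatter) not expected to exceed the scatter. For compound 4 in this assay the estimate is 80000 nM, with a range from 30000 nM to 200000 nM.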

Compound 4, concentration for 50% growth inhibition: 100000 nM
Estimate against measurement, compound 4: 1.3-fold (0.10 log units) below; the measured number falls inside the stated range.
By their numbers in this assay, from the lowest: compounds 1, 2, 3 and 4 (each within the scatter of the next).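

In this assay the position on a saturated chain carbon bound to an amide-type nitrogen in a ring now has a reading, and the step of a 1.5-fold higher number from compound 1 to compound 4 (0.17 log units; within the scatter) places 4-(1H-tetrazol-5-yl)butyl on the same flat level as 4-(1H-tetrazol-5-yl)phenyl. The six-membered aromatic ring of carbon only leaves this arm with the change while the tetrazole stays, so in this pair that ring is not required to keep the number on this level, and the flat record now covers a change to the arm as well as the changes to the biaryl ring and the thione. No measurement on these compounds offers an explanation for the flatness of this step.

From the compounds shown here alone, all four compounds carry the tetrazole, so it remains open whether a carboxylic acid or an amine in its place, or a chain longer than the 4-(1H-tetrazol-5-yl)butyl arm, would stay on this level or leave it. Going by these compounds, the benzyl ester is also common to all four, so whether a change at that group can move the number beyond the scatter remains open too.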